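Replacing 1,2-oxazol-5-yl on the core of compound 1

A few compounds are considered here, and "the series" means these few. Any claim that something is new, unique, unknown or untested is made for them only; others in the source may bear on it.

Measured so far in a physicochemical assay for lipophilicity, at pH 7.4; on this read-out lower numbers stand for lower lipophilicity and higher numbers for higher lipophilicity
- compound 1 `CC(C)Oc1ccc(-c2nnc(-c3ccno3)s2)cc1Cl` gives 6.93
- compound 2 `CC(C)Oc1ccc(-c2nnc(-n3cc4c(n3)CCN(CCCC(=O)O)C4)s2)cc1C#N` gives 2.87

Of these two, compound 1 (6.93) stands higher and compound 2 (2.87) lies lower by more than the usual scatter. The next compound to be read is compound 3 `CC(C)Oc1ccc(-c2nnc(-c3cncn3C)s2)cc1Cl`, which has no value yet. It departs from compound 1 in one place (1-methyl-1H-imidazol-5-yl in place of 1,2-oxazol-5-yl on an aromatic carbon), with 1-methyl-1H-imidazol-5-yl in place of 1,2-oxazol-5-yl on an aromatic carbon of a five-membered aromatic ring with 2 nitrogen and 1 sulfur.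

Within the data shown here, no two measured compounds differ in a single place, so the data offer no direct precedent for this exchange. A downward step beyond the scatter is still expected in this assay, since compound 1 starts from the top of the measured range (6.93). The expected size of the move is estimated as a number 1.33 log units lower from compound 1 to compound 3 (beyond the scatter) and remains a judgement. For compound 3 the estimate is 5.6 with an expected range from 4.8 to 6.4 until the measurement is in.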

Compound 3, distribution coefficient: 5.7
The estimate for compound 3 lay 0.10 log units below the measured number; the measured number falls inside the stated range.
By their numbers in this assay, from the lowest: compound 2; then compound 3; then compound 1.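

In this assay, among these compounds, the exchange of 1,2-oxazol-5-yl for 1-methyl-1H-imidazol-5-yl gives the first step in this set that can be read at a single place, a number 1.23 log units lower from compound 1 to compound 3 (beyond the scatter), and it lies beyond the usual scatter. It shows that this position, on an aromatic carbon of the shared core, is sensitive to swapping one five-membered aromatic ring with 2 hetero atoms for another, even though the two groups have the same counts of hydrogen-bond donors and acceptors and neither carries a net charge; what differs is the number of heavy atoms and their kinds, with the oxygen gone and a second nitrogen and an extra carbon present. No measurement on hand bears on why the number moves as it does.

With a single exchange at this place, the contributions of the ring itself and of its methyl group cannot be told apart, and the unmethylated 1H-imidazol-5-yl would bear directly on that question. Going by these compounds, how a six-membered ring such as pyridinyl or phenyl, or an open-chain amide, would read at the same position also remains open.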